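A few compounds are considered here, and "the series" means these few. Any claim that something is new, unique, unknown or untested is made for them only; others in the source may bear on it.

Series in a functional assay on A549 cells (Homo sapiens) for cytotoxicity, read by MTT assay, with a stated time of 48 h; on this read-out lower numbers stand for stronger inhibition and higher numbers for weaker inhibition:
- compound 1 `COc1ccc(-c2c(-c3cc(OC)c(OC)c(OC)c3)noc2N)cc1`: 4490 nM
- compound 2 `COc1ccc(-c2c(-c3cc(OC)c(OC)c(OC)c3)noc2NC(C)=O)cc1`: 10700 nM
- compound 3 `COc1ccc(-c2c(-c3cc(OC)c(OC)c(OC)c3)noc2N(C(C)=O)C(C)=O)cc1`: not yet measured

Of the two numbers in this assay, compound 2 has the higher at 10700 nM. Compound 3 differs from it by acetyl in place of hydrogen on an amide-type nitrogen, which is acetyl in place of hydrogen on an amide-type nitrogen. Going by the values given here, only one measured step bears on this change: a 2.4-fold higher number from compound 1 to compound 2 (0.38 log units; beyond the scatter). That modest step, beyond the scatter, also put acetyl in place of hydrogen on a nitrogen, though here the nitrogen already carries a carbonyl carbon. A single precedent gives a direction but only weak guidance on size, so a further modest rise is expected, with a wide margin. The expected step is a 1.4-fold higher number from compound 2 to compound 3 (0.15 log units; within the scatter). For compound 3 the estimated value is 15000 nM, with an expected range of 6000 nM to 40000 nM.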

Compound 3, half-maximal inhibitory concentration: 430 nM
Estimate against measurement, compound 3: 35-fold (1.54 log units) above; measured number below the stated range.
By their numbers in this assay, from the lowest: compound 3; then compound 1; then compound 2.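

In this assay a second acetyl on the amide-type nitrogen gives a 25-fold lower number from compound 2 to compound 3 (1.40 log units; beyond the scatter) and so runs opposite to the first acetyl, which gave a 2.4-fold higher number from compound 1 to compound 2 (0.38 log units; beyond the scatter). The net change, diacetylamino in place of amino, is a 10-fold lower number from compound 1 to compound 3 (1.02 log units; beyond the scatter), so across these three compounds the outcome of adding acetyl at this nitrogen depends on what the nitrogen already carries, and the two acetyl steps do not add up in one direction. Nothing measured here explains this reversal.

It remains open whether the gain is specific to two acetyl groups or extends to other pairs on this nitrogen, such as dipropionyl or acetyl with benzoyl. A methyl group in place of the remaining hydrogen of the acetamido group would show whether a second carbonyl is needed at all.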